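Shrinking the alkyl group on the cyanoguanidine nitrogen

The source may hold more compounds than are shown below. What is called first, only, known or untested is meant among the compounds shown, and "the series" means these compounds.

Compound 1, `CC(/N=C(\NC#N)Nc1ccccc1)C(C)(C)C`: 680 nM
Compound 2, `CC(C)(C)/N=C(\NC#N)Nc1ccc(C#N)cc1`: 480 nM
Compound 3, `CC(C)/N=C(\NC#N)Nc1ccc(C#N)cc1`: 7300 nM

In an assay on membranes from heart (Canis lupus familiaris) for displacement of a labelled ligand from sulfonylurea receptor 2, Kir6.2 (Homo sapiens) (a higher number here means a weaker inhibitor, a lower number a stronger inhibitor), compound 3 gives 7300 nM, the highest of the three numbers and so the weakest inhibitor of the set. Compound 1 gives 680 nM and compound 2 gives 480 nM, both lower than that of compound 3 by more than the scatter.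

Compound 4, `C/N=C(\NC#N)Nc1ccc(C#N)cc1`, differs from compound 3 by methyl in place of isopropyl on a double-bonded nitrogen. For the measured compounds named here, only one measured step bears on this change, and it is of the same kind: a 15-fold higher number from compound 2 to compound 3 (1.18 log units; beyond the scatter), where the loss of a methyl from the saturated chain carbon bound to the double-bonded nitrogen raised the number sharply. Going further in the same direction at the same place, from isopropyl to methyl, is therefore expected to raise the number again in this assay, by a step of a 5.5-fold higher number from compound 3 to compound 4 (0.74 log units; beyond the scatter) of comparable size, though only that single step supports the direction. Compound 4 is expected to give about 40000 nM, with a likely range from 10000 nM to 150000 nM, and with a real chance that this assay reports only a limit rather than a number.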

Compound 4, inhibition constant: > 30000 nM
Compound 4: only a limit was reported; the forecaster's own chance of this, stated with the estimate: 30%; the middle value is on the limit's open side.
By their numbers in this assay, from the lowest: compounds 2 and 1 (each within the scatter of the next); then compound 3. At a limit, above all of these: compound 4.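

In this assay compound 4 reaches only a limit of the assay and not a number: the limit of > 30000 nM in this assay, at which 1 of the 4 values shown sits. Replacing isopropyl with methyl on the double-bonded nitrogen still gives an at least 4.1-fold higher number from compound 3 to compound 4 (0.61 log units; beyond the scatter), and replacing tert-butyl with methyl at the same place gives an at least 62-fold higher number from compound 2 to compound 4 (1.79 log units; beyond the scatter). The earlier compounds shown here held a single step at this position, whereas tert-butyl, isopropyl and methyl now form a run of three groups in which the number rises with each shortening, and none of compounds 2, 3 and 4 goes against that order, although the last step is known only as a bound.

The compounds shown leave open whether the number would fall further with a group larger than tert-butyl on this nitrogen, such as a longer chain or a cyclohexyl ring, and whether a hydroxyl or an amine on the chain would fit the same order. As far as these compounds go, they also leave open how far the true value of compound 4 lies past its limit, so the full size of this change remains unknown.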